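A few compounds are considered here, and "the series" means these few. Any claim that something is new, unique, unknown or untested is made for them only; others in the source may bear on it.

Two compounds share one core and differ only in the group carried on the chain carbon bound to the ring nitrogen. Compound 1 `Cc1nc(C)c(CN2CCN(c3cccc4[nH]c(-c5ccc(C(C)(C)C)cc5)nc34)CC2)s1` gives 27 nM in an assay on isolated protein for displacement of a labelled ligand from Gonadotropin-releasing hormone receptor (Homo sapiens); on this read-out lower numbers stand for stronger inhibition and higher numbers for weaker inhibition. Among the measured compounds shown here, compound 2 `CCc1nc(C)c(CN2CCN(c3cccc4[nH]c(-c5ccc(C(C)(C)C)cc5)nc34)CC2)s1` gives 20 nM in this assay, the lowest of the two numbers, though its only neighbour is compound 1 and the step of a 1.4-fold lower number from compound 1 to compound 2 (0.13 log units; within the scatter) lies within the scatter. Compound 3 `Cc1nc(CN2CCN(c3cccc4[nH]c(-c5ccc(C(C)(C)C)cc5)nc34)CC2)c(C)s1` has not yet been measured. It differs from compound 2 by 2,5-dimethyl-1,3-thiazol-4-yl in place of 2-ethyl-4-methyl-1,3-thiazol-5-yl on a saturated chain carbon bound to an amine nitrogen in a ring. For the measured compounds named here, only the step from compound 1 to compound 2 bears on this, and only in part: it exchanged ethyl and methyl on the thiazole and stayed within the scatter, whereas compound 3 also moves the point where the thiazole joins the chain carbon, for which no measured step exists. The step expected from this change is a 1.8-fold higher number from compound 2 to compound 3 (0.24 log units; within the scatter). Compound 3 is therefore estimated at 35 nM in this assay, within a range from 12 nM to 100 nM.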

Compound 3, half-maximal inhibitory concentration: 21 nM
Beside the measured number, compound 3's estimate is 1.7-fold (0.22 log units) above it; low and high end bracket the measured number.
By their numbers in this assay, from the lowest: compounds 2, 3 and 1 (each within the scatter of the next).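

In this assay the change to 2,5-dimethyl-1,3-thiazol-4-yl in place of 2-ethyl-4-methyl-1,3-thiazol-5-yl gives a 1.1-fold higher number from compound 2 to compound 3 (0.02 log units; within the scatter) and the change to the same group in place of 2,4-dimethyl-1,3-thiazol-5-yl gives a 1.3-fold lower number from compound 1 to compound 3 (0.11 log units; within the scatter) as the second step. The earlier pair varied only methyl against ethyl on the thiazole, whereas these steps also change the ring atom through which the thiazole joins the saturated chain carbon, and for these three compounds that change leaves all the numbers within the scatter of one another. Nothing measured here offers an explanation for this result.

Going by these compounds, what remains open is whether this position stays as undemanding with something other than a dimethyl or ethyl-methyl thiazole. A thiazole carrying an amine or a longer chain, or a plain phenyl ring on the chain carbon, could still separate from these three.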